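This account rests on a few compounds, and the source may have more. Where it says the series, first, only, none or still open, it means among the compounds named here.

Compound 1 `CN(C)c1ccc(C#Cc2ccccc2)cc1` is the parent of the series. In a functional assay on LS174T cells (Homo sapiens) for antiproliferative activity, with a stated time of 4 days (on this read-out lower numbers stand for stronger inhibition and higher numbers for weaker inhibition), compound 1 reaches only the limit of > 3000 nM; it therefore sits at the limit of > 3000 nM in this assay, at which 1 of the 2 values shown sits, and no number is known for it. Compound 2 `CN(C)c1ccc(C#Cc2ccccc2Cl)cc1` carries a chloro on an aromatic carbon of the same ring, and in this assay compound 2 gives 31 nM. Going by the values given here, the single measured step, an at least 96-fold lower number from compound 1 to compound 2 (1.98 log units; beyond the scatter), is the only guide the series offers. Compound 3 `CN(C)c1ccc(C#Cc2cccc(F)c2)cc1` differs from compound 1 by fluoro in place of hydrogen on an aromatic carbon, meta to a large group. The chloro step bears on this change only loosely, since fluoro is another halogen and occupies a different place on the ring, so the size of that step cannot simply be carried over. A move toward a lower number is expected, but a smaller one, so compound 3 is expected to show an at least 2.5-fold lower number from compound 1 to compound 3 (0.39 log units; beyond the scatter). Compound 3 is accordingly estimated at 1200 nM in this assay, within 150 nM to 5000 nM, with a real chance that only a limit is returned again.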

Compound 3, half-maximal inhibitory concentration: > 3000 nM
Compound 3 gave a limit, no number; the forecaster's own chance of this, stated with the estimate: 40%; middle value at least 2.5-fold (0.39 log units) away from the limit.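

Compound 1 and compound 3 each return only a limit, not a number, in this assay, so the step between them cannot be read: the limit of > 3000 nM in this assay, at which 2 of the 3 values shown sit.

The compounds shown leave open whether fluoro changes activity at all, and whether the step to compound 2 depends on the halogen or on its place on the ring.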